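The source may hold more compounds than are shown below. What is called first, only, known or untested is meant among the compounds shown, and "the series" means these compounds.

Compound 1 `COC(=O)C1=C(C)N=C(C)/C(=C(/O)OC)C1c1cccc(N/C(=N/CCNC2CCN(c3ccccc3)CC2)NC#N)c1` and compound 2 `COC(=O)C1=C(C)N=C(C)/C(=C(/O)OC)C1c1cccc(N/C(=N/CCNC2CCN(c3ccccc3C)CC2)NC#N)c1` share one core and differ in one place. In an assay on SK-N-MC cells for inhibition of Neuropeptide Y receptor type 1 (Homo sapiens) (on this read-out lower numbers stand for stronger inhibition and higher numbers for weaker inhibition), compound 1 gives 10 nM, the higher of the two numbers shown, while compound 2 gives 4 nM, which is a 2.5-fold lower number from compound 1 to compound 2 (0.40 log units; beyond the scatter). Compound 3 `COC(=O)C1=C(C)N=C(C)/C(=C(/O)OC)C1c1cccc(N/C(=N/CCNC2CCN(c3ccccc3SC)CC2)NC#N)c1` carries methylsulfanyl in place of hydrogen on an aromatic carbon. Going by the values given here, only the step from compound 1 to compound 2 bears on this change, so a modest move in the same direction, lower numbers meaning stronger inhibition, is expected, roughly a 1.7-fold lower number from compound 1 to compound 3 (0.22 log units; within the scatter). For compound 3 the estimated value in this assay is 6 nM, within a range from 2.5 nM to 15 nM.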

Compound 3, half-maximal inhibitory concentration: 3 nM
The estimate for compound 3 lay 2.0-fold (0.30 log units) above the measured number, and the stated range covers the measured number.
By their numbers in this assay, from the lowest: compounds 3 and 2 (each within the scatter of the next); then compound 1.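

In this assay, methylsulfanyl in place of hydrogen on this aromatic carbon gives a 3.3-fold lower number from compound 1 to compound 3 (0.52 log units; beyond the scatter), so the gain seen with methyl extends to a second, larger group. Methylsulfanyl in place of methyl gives a 1.3-fold lower number from compound 2 to compound 3 (0.12 log units; within the scatter), so the two groups cannot be told apart at this position. No supporting data speak to the reason for this result.

From the compounds shown here alone, whether a chlorine atom, an amine or a longer chain such as ethylsulfanyl would fit this position equally well remains open. So does the effect of methylsulfanyl elsewhere on this ring.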